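The source may report more compounds than this note shows. Statements on the series, on what has been measured and on what is new or still open speak of the compounds shown alone.

Compound 2 `Cc1cccc2c(-c3ccc4ccccc4n3)c[nH]c12` is the unsubstituted member of the first pair; in an ADME assay on microsomes from liver (Homo sapiens) for metabolic stability, using NADPH, with a stated time of 40 min, tested at 2 uM (on this read-out lower numbers stand for a shorter-lived compound and higher numbers for a longer-lived compound), compound 2 gives 0.35 h. Compound 1 `CNC(=O)c1cccc2nc(-c3c[nH]c4c(C)cccc34)ccc12` differs from it by methylcarbamoyl in place of hydrogen on an aromatic carbon and in this assay compound 1 gives 0.983 h. That single change made a 2.8-fold higher number from compound 2 to compound 1 (0.45 log units; beyond the scatter).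

Compound 3 `Fc1cc2c(-c3ccc4ccccc4n3)c[nH]c2c(F)c1F` is built on a different core; the difference between the two cores is not broken down here. In this assay compound 3 gives 0.25 h. Compound 3 and compound 2 lie within the usual scatter of each other, so their two values show no order between them.

Compound 4 `CNC(=O)c1cccc2nc(-c3c[nH]c4c(F)c(F)c(F)cc34)ccc12` has not been measured. It differs from compound 3 by methylcarbamoyl in place of hydrogen on an aromatic carbon. The place is described in the same words as for the change from compound 2 to compound 1, so this is the same change, occurring twice among the compounds shown, once measured and once not.

Going by the values given here, the step from compound 3 to compound 4 is expected to be of similar size, a 2.8-fold higher number from compound 3 to compound 4 (0.45 log units; beyond the scatter), because the one measured instance of this change gave a 2.8-fold higher number from compound 2 to compound 1 (0.45 log units; beyond the scatter). Among the compounds with values here, whether the other core carries the change in the same way is not known from these data; only one pair supports the transfer, so the range is kept wide. Compound 4 is expected to give 0.7 h in this assay, estimated between 0.35 h and 1.4 h.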

Compound 4, half-life: 1.17 h
Compound 4: the middle estimate sits 1.7-fold (0.22 log units) below what was measured; low and high end bracket the measured number.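

In this assay, methylcarbamoyl in place of hydrogen on an aromatic carbon gives a 4.7-fold higher number from compound 3 to compound 4 (0.67 log units; beyond the scatter) and so moves the half-life in the same direction on the second core as on the first. The two steps cannot be told apart, so between these two cores the change carries over with no detectable dependence on the core: the same change on two cores in this assay, a 2.8-fold higher number (0.45 log units; beyond the scatter) from compound 2 to compound 1 and a 4.7-fold higher number (0.67 log units; beyond the scatter) from compound 3 to compound 4, 1.7-fold (0.22 log units) apart, within the scatter of two such steps. This rests on two pairs, a single read-out and one place on the ring, so it does not show that the step would hold on any further core, and it does not show which part of the methylcarbamoyl group accounts for the longer half-life.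

The compounds shown leave open whether another group in the same place, such as a plain carbamoyl without the methyl, an amide with a longer chain on its nitrogen, a carboxylic acid or an amine, would give a step of similar size. They also leave open whether methylcarbamoyl on a different aromatic carbon of the same ring would lengthen the half-life to the same extent, or whether that depends on the place it occupies.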